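Butyl for Isopropyl on the Amide of Compound 2

The compounds below may be only part of what the source reports. "The series", "measured", "known", "first", "only" and "open" are said of these compounds alone.

Of the compounds shown here, two share a core and have been tested in a functional assay on K562 cells (Homo sapiens) for antiproliferative activity, read by CCK-8 assay, with a stated time of 72 h; a lower number here means a stronger inhibitor of growth, a higher number a weaker inhibitor of growth. Compound 1 `CC[C@@H]1C(=O)N(C)c2cnc(Nc3ccc(S(N)(=O)=O)cc3)nc2N1C1CCCC1` carries a sulfonamide-bearing aniline on that core, and in this assay compound 1 gives 470 nM. Compound 2 `CC[C@@H]1C(=O)N(C)c2cnc(-n3ccc4cc(C(=O)NC(C)C)ccc43)nc2N1C1CCCC1` instead carries an indole bearing an isopropylcarbamoyl group, and in this assay compound 2 gives 786 nM. Of the two numbers shown, compound 2 stands at the upper end, yet its distance to compound 1 lies within the usual scatter of repeated measurements, so the two cannot be told apart on these data.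

Compound 3 `CCCCNC(=O)c1ccc2c(ccn2-c2ncc3c(n2)N(C2CCCC2)[C@H](CC)C(=O)N3C)c1` has not yet been measured. It differs from compound 2 in one place: butyl in place of isopropyl on an amide-type nitrogen. Among the measured compounds shown here, no measured pair shows what exchanging one small alkyl chain for another on this amide-type nitrogen does, so nothing in the data points to a direction. The expected step of a 1.0-fold higher number from compound 2 to compound 3 (0.01 log units; within the scatter) is therefore none beyond the scatter. Compound 3 is estimated to give about 800 nM in this assay, with a plausible range from 350 nM to 1800 nM.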

Compound 3, concentration for 50% growth inhibition: 673 nM
Beside the measured number, compound 3's estimate is 1.2-fold (0.08 log units) above it; the measured number falls inside the stated range.
By their numbers in this assay, from the lowest: compounds 1, 3 and 2 (each within the scatter of the next).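

Among the compounds shown here, this is the first pair that differs only in the alkyl chain on the amide-type nitrogen, so it gives the first direct reading of this position in this assay. Butyl in place of isopropyl, a change of one carbon that adds no ring, no hydrogen-bond donor or acceptor and no net charge, gives a 1.2-fold lower number from compound 2 to compound 3 (0.07 log units; within the scatter), so the two compounds cannot be told apart in growth inhibition and this exchange leaves no readable mark on the result. Nothing in the data speaks to why this is so, and no separate measurement bears on this pair.

As far as these compounds go, a single exchange between two small alkyl chains shows only how little these two differ, so it remains open whether this position would respond to a much longer chain such as octyl, a ring such as phenyl, or a chain ending in an amine or a carboxylic acid. Any of these could give a step beyond the scatter or none at all, and the compounds shown do not indicate which.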